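A few compounds are considered here, and "the series" means these few. Any claim that something is new, unique, unknown or untested is made for them only; others in the source may bear on it.

Measured compounds:
Compound 1, `NS(=O)(=O)c1ccc(NC(=S)Nc2ccc3ncnc(Nc4ccc(F)c(Cl)c4)c3c2)cc1`: 15800 nM
Compound 2, `NS(=O)(=O)c1ccc(NC(=S)Nc2ccc3ncnc(Nc4ccc(Cl)c(C(F)(F)F)c4)c3c2)cc1`: 11800 nM

Both were tested in a functional assay on NCI-H1975 cells (Homo sapiens) for antiproliferative activity, read by MTT assay, with a stated time of 72 h; on this read-out higher numbers stand for weaker inhibition and lower numbers for stronger inhibition. Compound 2 gives 11800 nM there, and compound 1 gives 15800 nM; the step of a 1.3-fold lower number from compound 1 to compound 2 (0.13 log units; within the scatter) is within the scatter, so compound 2 stands alongside compound 1 rather than apart from it. Compound 3, `NS(=O)(=O)c1ccc(NC(=S)Nc2ccc3ncnc(Nc4ccc(F)c(Br)c4)c3c2)cc1`, is the next member of the series, differing from compound 2 by 3-bromo-4-fluorophenyl in place of 4-chloro-3-(trifluoromethyl)phenyl on a nitrogen on an aromatic ring. For the measured compounds named here, the only step that bears on this is the exchange of one substituted phenyl ring for another between compound 1 and compound 2, a 1.3-fold lower number from compound 1 to compound 2 (0.13 log units; within the scatter), which did not move the number beyond the scatter, and compound 3 carries a ring closer in kind to that of compound 1 than to that of compound 2. A step of similar size, or none beyond the scatter, is therefore expected, a 1.1-fold higher number from compound 2 to compound 3 (0.06 log units; within the scatter). Compound 3 is estimated at 13500 nM, between 5500 nM and 33000 nM.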

Compound 3, half-maximal inhibitory concentration: 9980 nM
Estimate against measurement, compound 3: 1.4-fold (0.13 log units) above; the measured number falls inside the stated range.
By their numbers in this assay, from the lowest: compounds 3, 2 and 1 (each within the scatter of the next).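

Putting 3-bromo-4-fluorophenyl in place of 4-chloro-3-(trifluoromethyl)phenyl on a nitrogen on an aromatic ring gives a 1.2-fold lower number from compound 2 to compound 3 (0.07 log units; within the scatter) in this assay and so adds a third ring that stays within the scatter at this position. The closest comparison yet, bromo in place of chloro on an aromatic carbon, gives a 1.6-fold lower number from compound 1 to compound 3 (0.20 log units; within the scatter) and likewise does not set the compounds apart. Nothing available explains why these exchanges leave the numbers together.

Going by these compounds, whether the same holds for a phenyl ring carrying an amine or a carboxylic acid, or for a phenyl ring with no halogen at all, stays open. Also open, on these data alone, is whether a change elsewhere in the shared core would move the number beyond the scatter.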